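Adding a Methoxy Group: One Change, Two Settings

A few compounds are considered here, and "the series" means these few. Any claim that something is new, unique, unknown or untested is made for them only; others in the source may bear on it.

Compound 1 `COc1cc(Nc2nc3ccccc3nc2S(=O)(=O)c2ccc(C)cc2)cc(OC)c1` and compound 2 `COc1cc(Nc2nc3ccccc3nc2S(=O)(=O)c2ccc(C)cc2)cc(OC)c1OC` share a core and differ in one place: methoxy in place of hydrogen on an aromatic carbon. In a functional assay on A549 cells (Homo sapiens) for cytotoxicity, read by MTT assay, with a stated time of 72 h (a lower number here means a stronger inhibitor, a higher number a weaker inhibitor), compound 1 gives 8060 nM, and compound 2 gives 5610 nM. The step is a 1.4-fold lower number from compound 1 to compound 2 (0.16 log units; within the scatter), so the two numbers cannot be told apart by a measurement of this kind.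

Compound 3 `COc1ccc(S(=O)(=O)c2nc3ccccc3nc2Nc2ccccc2)cc1` rests on a core whose difference from compound 1 is not broken down here. In this assay compound 3 gives 13200 nM; set against compound 1 and compound 2, it stands as the highest of the three numbers, close to compound 1 within the scatter, while the gap to compound 2 lies beyond the scatter.

Compound 4 `COc1ccc(Nc2nc3ccccc3nc2S(=O)(=O)c2ccc(OC)cc2)cc1` has not yet been measured. It arises from compound 3 by the same kind of change: methoxy in place of hydrogen on an aromatic carbon. The setting is not identical, though: in compound 1 the place sits ortho to two methoxy groups and para to a large group, whereas in compound 3 it sits only para to a large group.

The expected step is a 1.4-fold lower number from compound 3 to compound 4 (0.14 log units; within the scatter), resting on a 1.4-fold lower number from compound 1 to compound 2 (0.16 log units; within the scatter), which stayed within the scatter of repeated measurements. Compound 4 is therefore expected to give about 9500 nM in this assay, with a likely range from 4000 nM to 22000 nM.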

Compound 4, half-maximal inhibitory concentration: 8260 nM
Compound 4: middle estimate off by 1.2-fold (0.06 log units), on the high side, within the range that was stated.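

In this assay, the new step is a 1.6-fold lower number from compound 3 to compound 4 (0.20 log units; within the scatter), so compound 3 and compound 4 cannot be told apart by a measurement of this kind. Placed beside the earlier step, the same change gives steps on the two cores that cannot be separated from each other: the same change on two cores in this assay, a 1.4-fold lower number (0.16 log units; within the scatter) from compound 1 to compound 2 and a 1.6-fold lower number (0.20 log units; within the scatter) from compound 3 to compound 4, 1.1-fold (0.05 log units) apart, within the scatter of two such steps This shows only that, in these two pairs, swapping hydrogen for methoxy on an aromatic carbon leaves the number within the scatter on both cores; it does not show that methoxy truly lowers the number on either core, and two small steps that agree do not make a rule for other cores in the series.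

The compounds shown leave open whether a different group at this place, such as an amine, a carboxylic acid or a longer chain like butoxy, would give a step that clearly stands beyond the scatter. As far as these compounds go, it also remains open whether the small steps seen in this assay would look the same in other cell types, since every number here comes from this one test.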